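Adding a Second Chloro Group to Compound 3

The compounds below may be only part of what the source reports. "The series", "measured", "known", "first", "only" and "open" are said of these compounds alone.

Measured in a functional assay on Hep cells (Homo sapiens) for cytotoxicity, read by sulforhodamine B assay, with a stated time of 48 h; a lower number here means a stronger inhibitor, a higher number a weaker inhibitor:
Compound 1 (`C=CCOc1c(Cl)cccc1C(=O)c1cccnc1`) 92000 nM
Compound 2 (`O=C(c1cccnc1)c1cc(Cl)cc(Cl)c1O`) 27000 nM
Compound 3 (`C=CCOc1ccc(Cl)cc1C(=O)c1cccnc1`) > 100000 nM (a limit)

Compound 3 gives no number, only a limit (the limit of > 100000 nM in this assay, at which 1 of the 3 values shown sits). Compound 4 (`C=CCOc1c(Cl)cc(Cl)cc1C(=O)c1cccnc1`) is compound 3 with a single change (chloro in place of hydrogen on an aromatic carbon), chloro in place of hydrogen on an aromatic carbon. The new group sits ortho to an allyloxy group and meta to a chloro group.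

For the measured compounds named here, no pair of measured compounds differs in just one place, so any expectation rests on their values alone. Compound 1 (92000 nM) already carries a chloro group ortho to an allyloxy group and gives a number, though a high one. Compound 2 (27000 nM) carries the same chloro groups as compound 4 but no allyloxy group, and its value lies lower than that of compound 1. Compound 4 shares features with both, so it is expected to move off the limit, but only modestly. The expected change is an at least 1.8-fold lower number from compound 3 to compound 4 (0.25 log units; that floor lies within the scatter) and it points toward stronger inhibition. The estimated value for compound 4 is 55000 nM with an expected range from 20000 nM to 100000 nM in this assay and a reading at the limit remains possible.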

Compound 4, half-maximal inhibitory concentration: > 100000 nM
Compound 4 gave a limit, no number; the forecaster's own chance of this, stated with the estimate: 30%; at least 1.8-fold (0.25 log units) between middle value and limit.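

In this assay compound 4 gives only a limit, as compound 3 does, so the step for the new chloro group ortho to an allyloxy group cannot be read: the limit of > 100000 nM in this assay, at which 2 of the 4 values shown sit.

The other two steps say more. Allyl in place of hydrogen on the oxygen on the aromatic ring gives an at least 3.7-fold higher number from compound 2 to compound 4 (0.56 log units; beyond the scatter), so with both chloro groups present, the compound with the free oxygen gives the lower number and the allyl compound the higher, a difference that none of the earlier compounds could show in a single change. Chloro in place of hydrogen on an aromatic carbon gives an at least 1.0-fold higher number from compound 1 to compound 4 (0.03 log units; that floor lies within the scatter), and since that floor lies within the scatter, this second chloro group brings no sign of stronger inhibition in compound 4.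

The compounds shown leave open how far above the limit compound 3 and compound 4 lie, and so whether the new chloro group has any effect on the number at all. They also leave open whether a methyl group or a longer chain ending in an amine on the same oxygen would keep the lower number of compound 2 or follow the allyl compounds.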